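Swapping the acid for a tetrazole on a stability-tested amide

The compounds below may be only part of what the source reports. "The series", "measured", "known", "first", "only" and "open" are said of these compounds alone.

Measured compounds:
- compound 1 `C[C@]1(C(=O)N2CC[C@](c3ccc(C(F)(C(F)(F)F)C(F)(F)F)cc3)(S(=O)(=O)c3ccc(F)cc3)C2)CC[C@H](C(=O)O)CC1`: 80%
- compound 2 `O=C(O)C1CCC(O)(C(=O)N2CC[C@](c3ccc(C(F)(C(F)(F)F)C(F)(F)F)cc3)(S(=O)(=O)c3ccc(F)cc3)C2)CC1`: 100%; 95% (2 entries)
- compound 3 `O=C(O)C12CCC(C(=O)N3CC[C@](c4ccc(C(F)(C(F)(F)F)C(F)(F)F)cc4)(S(=O)(=O)c4ccc(F)cc4)C3)(CC1)CC2`: 100%

All three compounds share one core and differ only in the ring-bearing acid attached to the carbonyl carbon. In an ADME assay on microsomes from liver (Homo sapiens) for metabolic stability, with a stated time of 10 min (a lower number here means that less of the compound is left, a higher number that more of the compound is left), compound 1 gives 80%, the lowest of the two single numbers, with compound 3 nearest at 100%. Among the compounds with values here, the only step measured here, a number 20 percentage points higher from compound 1 to compound 3 (beyond the scatter), goes in the direction of more compound remaining. Compound 2 was run more than once, (the several entries of compound 2 in this assay, 100%; 95% (2 entries)), and its values sit close together.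

Compound 4 `O=C([C@H]1CC[C@H](c2nnn[nH]2)CC1)N1CC[C@](c2ccc(C(F)(C(F)(F)F)C(F)(F)F)cc2)(S(=O)(=O)c2ccc(F)cc2)C1` is not yet measured. It differs from compound 1 in one place: 4-(1H-tetrazol-5-yl)cyclohexyl in place of 4-carboxy-1-methylcyclohexyl on a carbonyl carbon.

Within the data shown here, no measured step changes a carboxylic acid into a tetrazole, so nothing here bears directly on this change. Among the measured compounds shown here, the one step that is known concerns a different alteration on the same carbonyl carbon, and it was modest in size. For compound 4 a step of a number 2 percentage points higher from compound 1 to compound 4 (within the scatter) is expected, which stays within the scatter in this assay. The estimate for compound 4 is therefore 82%, with a range from 55% to 100%.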

Compound 4, percent of the compound remaining: 100%
The estimate for compound 4 lay 18 percentage points below the measured number; measured number inside the range.
By their numbers in this assay, from the lowest: compound 1; then compounds 3 and 4 (each within the scatter of the next).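

In this assay, replacing 4-carboxy-1-methylcyclohexyl with 4-(1H-tetrazol-5-yl)cyclohexyl on the carbonyl carbon gives a number 20 percentage points higher from compound 1 to compound 4 (beyond the scatter), so a group without a carboxylic acid can stand at this position and still leave as much compound as the best acids shown. Set against the other acid, the tetrazole gives no change at the digits printed from compound 3 to compound 4 (within the scatter), which means that two quite different groups at this position, one with two carbon rings and a carboxylic acid and one with a single carbon ring and a tetrazole, cannot be told apart in this read-out. The step from compound 1 also makes two changes at once, since the methyl group goes along with the acid, so its size cannot be credited to the tetrazole alone.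

A plain 4-carboxycyclohexyl group, with neither the methyl nor the tetrazole, would separate those two changes, and that comparison is open here. Also open are how a primary amide or a sulfonamide would behave at this position and how finely compounds near the top of the scale can be ranked, given how far repeat runs spread: the several entries of compound 2 in this assay, 100%; 95% (2 entries)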